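Replacing methoxy with ((thiophen-2-yl)methyl)amino on the carbonyl carbon

This account rests on a few compounds, and the source may have more. Where it says the series, first, only, none or still open, it means among the compounds named here.

In a functional assay on HEY cells (Homo sapiens) for cytotoxicity, read by MTT assay, with a stated time of 72 h (a lower number here means a stronger inhibitor, a higher number a weaker inhibitor), compound 3 `COC(=O)c1nc(Br)c2cccnc2c1N[C@H]1CC[C@H](N)CC1` gives > 20000 nM, which is a limit and not a number. Compound 4 `N[C@H]1CC[C@H](Nc2c(C(=O)NCc3cccs3)nc(Br)c3cccnc23)CC1` carries ((thiophen-2-yl)methyl)amino in place of methoxy on a carbonyl carbon. Compound 1 `N[C@H]1CC[C@H](Nc2c(C(=O)NCc3ccco3)nc(Br)c3cccnc23)CC1`, with ((furan-2-yl)methyl)amino there, gives > 10000 nM, also a limit. Compound 2 `N[C@H]1CC[C@H](Nc2c(C(=O)NCc3ccc(Cl)cc3)nc(Br)c3cccnc23)CC1`, with (4-chlorobenzyl)amino there, gives 1000 nM. The closest large change is an at least 20-fold higher number from compound 2 to compound 3 (1.30 log units; beyond the scatter), and the aryl swap is an at least 10-fold lower number from compound 1 to compound 2 (1.00 log units; beyond the scatter). The five-membered ring of compound 1 offers no firm guide, since a step that the two limits leave unreadable from compound 1 to compound 3. A lower number of moderate size is therefore expected, with an at least 4.0-fold lower number from compound 3 to compound 4 (0.60 log units; beyond the scatter) as the estimated step. For compound 4 the estimate is 5000 nM, with an expected range of 1500 nM to 15000 nM.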

Compound 4, half-maximal inhibitory concentration: 11000 nM
Compound 4: middle estimate off by 2.2-fold (0.34 log units), on the low side; the measured number falls inside the stated range.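

In this assay, there is an at least 1.8-fold lower number from compound 3 to compound 4 (0.25 log units; that floor lies within the scatter), a floor within the scatter, so ((thiophen-2-yl)methyl)amino is not shown to improve on methoxy at this carbonyl carbon. There is also an 11-fold higher number from compound 2 to compound 4 (1.04 log units; beyond the scatter), so the amide link alone does not account for the value of compound 2, and the group on the saturated chain carbon matters. The step between compound 1 and compound 4 cannot be read, because compound 1 stands only as a limit: the limit of > 10000 nM in this assay, at which 1 of the 4 values shown sits.

The compounds shown leave open whether the chlorine or the phenyl ring sets compound 2 apart. A plain benzylamino group or a (5-chlorothiophen-2-yl)methylamino group would separate the two.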